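Swapping an aryl amide for a thiazole: a cytotoxicity check

This account rests on a few compounds, and the source may have more. Where it says the series, first, only, none or still open, it means among the compounds named here.

Measured compounds:
Compound 1, `CSc1ccc2nc(C)cc(OCC(=O)Nc3cc(C)cc(C)c3)c2c1`, > 100000 nM in a toxicity assay on HepG2 cells (Homo sapiens) for inhibition, read by CellTiter-Glo, with a stated time of 48 h (a higher number here means a weaker inhibitor, a lower number a stronger inhibitor), a value that is a limit of the assay.
Compound 2, `Cc1cc(C)cc(NC(=O)COc2cc(C)nc3ccc(F)cc23)c1`, 63100 nM in this assay.
Compound 3, `COc1ccc(NC(=O)COc2cc(C)nc3ccc(OC)cc23)cc1`, > 100000 nM in this assay, which is again a limit of the assay rather than a number.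

Compound 3 therefore stands among the weakest inhibitors shown, sitting at the limit of > 100000 nM in this assay, at which 2 of the 3 values shown sit. Compound 4, `COc1ccc2nc(C)cc(OCC(=O)Nc3nc(C)c(C)s3)c2c1`, has not yet been measured. It differs from compound 3 by 4,5-dimethyl-1,3-thiazol-2-yl in place of 4-methoxyphenyl on an amide-type nitrogen. For the measured compounds named here, the only measured step, an at least 1.5-fold lower number from compound 1 to compound 2 (0.19 log units; that floor lies within the scatter), concerns a change on an aromatic carbon of the shared core, not the amide nitrogen, and its floor lies within the scatter, so it gives little guidance. Going by the values given here, with no step bearing directly on this change, compound 4 is expected to stay near the limit, with a step of a number no higher from compound 3 to compound 4 (the limit leaves the size open) in this assay. Compound 4 is thus estimated at 100000 nM, ranging from 40000 nM to 250000 nM.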

Compound 4, half-maximal inhibitory concentration: > 100000 nM
Compound 4: only a limit was reported; the forecaster's own chance of this, stated with the estimate: 70%; the middle value sits exactly at the limit.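

Compound 3 and compound 4 both give only a limit of the assay, so the step between them cannot be read: the limit of > 100000 nM in this assay, at which 3 of the 4 values shown sit. The compounds shown leave open whether 4,5-dimethyl-1,3-thiazol-2-yl in place of 4-methoxyphenyl changes the number in this assay at all.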